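The compounds below may be only part of what the source reports. "The series", "measured", "known", "first", "only" and "open" are said of these compounds alone.

Measured compounds:
compound 1 `CCCc1cc(OCCCOc2ccc(C(C)=O)c(OC)c2CCC)cc2c1OC(C(=O)O)CC2` gives 22 nM in an assay on lung parenchyma (Cavia porcellus) with leukotriene B4 receptor 1 (Homo sapiens) as the target; a higher number here means a weaker inhibitor, a lower number a stronger inhibitor
compound 2 `CCCc1c(OCCCOc2cc(O)c(C(C)=O)cc2CC)cccc1OCC(=O)O` gives 30 nM in this assay

Compound 2 gives the higher of the two numbers, and its nearest neighbour, compound 1, lies within the scatter of it. Compound 3 `CCCc1c(OCCCOc2cc(O)c(C(C)=O)cc2CC)cccc1OC(C)C(=O)O` differs from compound 2 in one place: methyl in place of hydrogen on a saturated chain carbon bound to a carbonyl carbon and an oxygen on an aromatic ring. Going by the values given here, no measured pair shows this change, so its size is unknown. No step beyond the scatter is expected in this assay in either direction. Compound 3 is therefore estimated at 25 nM, within 10 nM to 70 nM, the estimated step of a 1.2-fold lower number from compound 2 to compound 3 (0.08 log units; within the scatter) being small.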

Compound 3, antagonist equilibrium constant: 75.8 nM
The estimate for compound 3 lay 3.0-fold (0.48 log units) below the measured number; measured number outside the range, above it.
By their numbers in this assay, from the lowest: compounds 1 and 2 (each within the scatter of the next); then compound 3.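

In this assay this carbon proved sensitive to substitution: going from carboxymethoxy to 1-carboxyethoxy gives a 2.5-fold higher number from compound 2 to compound 3 (0.40 log units; beyond the scatter) and is the first step beyond the scatter among these compounds. A single added methyl at this position therefore moves compound 3 towards a weaker inhibitor. Nothing available accounts for this loss.

As far as these compounds go, whether an ethyl group or a longer chain at this carbon would weaken inhibition further remains open. So does whether a second methyl or a hydroxyl group there would be tolerated.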